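The source may report more compounds than this note shows. Statements on the series, on what has been measured and on what is new or still open speak of the compounds shown alone.

Measured compounds:
compound 1 `CCCNc1nc2ccccc2c(NCc2ccc(NC(=O)c3ccc(F)cc3)cc2)c1C#N` — > 20000 nM in a functional assay on SW480 cells (Homo sapiens) for inhibition, read by luminescence and resazurin assay, with a stated time of 3 days; on this read-out higher numbers stand for weaker inhibition and lower numbers for stronger inhibition (a limit, not a number)
compound 2 `Cc1ccc(S(=O)(=O)Nc2ccc(CNc3nc(N(C)C)nc4ccccc34)cc2)cc1` — 13000 nM
compound 3 `CCNc1ncc(C)c(NCc2ccc(NC(=O)c3ccc(F)cc3)cc2)n1` — > 20000 nM (again a limit)

Among the measured compounds shown here, compound 2 stands as the only compound of the three that gives a number in this assay. Compound 1 and compound 3 both sit at the limit of > 20000 nM in this assay, at which 2 of the 3 values shown sit.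

Compound 4 `CN(C)c1nc(NCc2ccc(NC(=O)c3ccncc3)cc2)c2ccccc2n1` has not been measured. It differs from compound 2 by (pyridin-4-yl)carbonyl in place of (4-methylphenyl)sulfonyl on a nitrogen on an aromatic ring. For the measured compounds named here, no measured pair here differs in only one place, so no step size is known directly. Compound 1 and compound 3 also carry an amide on that nitrogen, and both sit at the limit. The step is therefore expected to run toward weaker inhibition, beyond the scatter: a 1.9-fold higher number from compound 2 to compound 4 (0.28 log units; within the scatter). Compound 4 is estimated at 25000 nM, within 8000 nM to 60000 nM, with a real chance that only a limit is reported.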

Compound 4, half-maximal inhibitory concentration: 11000 nM
Compound 4: the middle estimate sits 2.3-fold (0.36 log units) above what was measured, and the stated range covers the measured number.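

Swapping (4-methylphenyl)sulfonyl for (pyridin-4-yl)carbonyl on this nitrogen gives a 1.2-fold lower number from compound 2 to compound 4 (0.07 log units; within the scatter) in this assay. On this core, then, the sulfonyl group is not needed for a measurable number, and a carbonyl group with a pyridine ring serves equally well. Compound 4 gives a true number and stays clear of the limit: the limit of > 20000 nM in this assay, at which 2 of the 4 values shown sit.

From the compounds shown here alone, what remains open is how a much smaller group on the same nitrogen, such as acetyl or simply a free amine, would behave. It is also unknown whether any group at this position can give clearly stronger inhibition.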